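A few compounds are considered here, and "the series" means these few. Any claim that something is new, unique, unknown or untested is made for them only; others in the source may bear on it.

Measured in an ADME assay on SH-SY5Y cells (Homo sapiens) for cytotoxicity, read by MTT assay, with a stated time of 48 h; on this read-out lower numbers stand for an effect already at smaller amounts and higher numbers for an effect only at larger amounts of compound:
- compound 1 `O=C(O)c1ccccc1-c1ccccc1C(=O)NCCCCCCCn1cc(-c2cccnc2)nn1`: > 500 nM (a limit)
- compound 2 `O=C(O)c1cccc(-c2ccccc2C(=O)NCCCCCCCn2cc(-c3cccnc3)nn2)c1`: > 500 nM (a limit)
- compound 3 `O=C(NCCCCCCCn1cc(-c2cccnc2)nn1)c1ccccc1-c1c[nH]nn1`: 86.5 nM

Of these three results, only compound 3 has an actual number, at 86.5 nM. The other two results are limits, so compound 3 cannot be placed precisely against them.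

The next compound is compound 4 `O=C(NCCCCCCCn1cc(-c2cccnc2)nn1)c1ccccc1-n1cc(CN2CCCC2)nn1`. It changes one group of compound 3: 4-((pyrrolidin-1-yl)methyl)-1H-1,2,3-triazol-1-yl in place of 1H-1,2,3-triazol-4-yl on an aromatic carbon.

For the measured compounds named here, three measured steps touch this place on an aromatic carbon. The step that the two limits leave unreadable from compound 1 to compound 2 gives no size. The steps of an at least 5.7-fold lower number from compound 1 to compound 3 (0.76 log units; beyond the scatter) and an at least 5.7-fold lower number from compound 2 to compound 3 (0.76 log units; beyond the scatter) are both beyond the scatter, and both replace a carboxyphenyl group with 1H-1,2,3-triazol-4-yl. Compound 4 also lacks a carboxyphenyl group and keeps a five-membered aromatic ring with 3 hetero atoms, so a result near compound 3 is expected, rather than a return to the limit. Going by the values given here, no measured step covers the added pyrrolidine, so the uncertainty is wide, and neither direction is favoured with confidence.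

The expected step is a 1.3-fold higher number from compound 3 to compound 4 (0.10 log units; within the scatter), which is not expected to stand clearly beyond the scatter. For compound 4 the estimated value is 110 nM, with an expected range from 20 nM to 500 nM.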

Compound 4, half-maximal effective concentration: > 10000 nM
Compound 4: a limit, no number; the forecaster's own chance of this, stated with the estimate: 20%; middle value at least 90-fold (1.95 log units) away from the limit.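

In this assay, this position on an aromatic carbon, ortho to a large group, proves highly sensitive to the group placed there: 4-((pyrrolidin-1-yl)methyl)-1H-1,2,3-triazol-1-yl in place of 1H-1,2,3-triazol-4-yl gives an at least 110-fold higher number from compound 3 to compound 4 (2.06 log units; beyond the scatter). The result for compound 4 is a limit, not a number: the limit of > 10000 nM in this assay, at which 1 of the 4 values shown sits.

Compound 3 and compound 4 both carry a five-membered aromatic ring with 3 hetero atoms, so that ring alone does not secure the low number seen with compound 3.

On these data alone, the steps from compound 1 and compound 2 to compound 4 cannot be read, as each pair has only limits, so their order remains open. Also open, as far as these compounds go, is whether the pyrrolidine or the change from a 4-yl to a 1-yl link drives the step, which an unsubstituted 1H-1,2,3-triazol-1-yl group could help separate.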